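Hydrazone condensation on a thiosemicarbazide: cytotoxicity in breast cancer cells

The source may report more compounds than this note shows. Statements on the series, on what has been measured and on what is new or still open speak of the compounds shown alone.

Compound 1 `CC1=CC[C@@H]([C@@](C)(O)CCCC(C)(C)NC(=S)NN)CC1` reaches only the limit of a functional assay on MCF7 cells (Homo sapiens) for cytotoxicity, read by sulforhodamine B assay (a lower number here means that less compound is tolerated, a higher number that more compound is tolerated), giving > 100000 nM; this is a limit, not a number (the limit of > 100000 nM in this assay, at which 1 of the 2 values shown sits). Compound 2 `CC1=CC[C@@H]([C@@](C)(O)CCCC(C)(C)NC(=S)N/N=C\c2cccc(Cl)c2)CC1` gives 45900 nM in this assay, and the step of an at least 2.1-fold lower number from compound 1 to compound 2 (0.33 log units; beyond the scatter) goes toward more toxicity. Compound 3 `CC1=CC[C@@H]([C@@](C)(O)CCCC(C)(C)NC(=S)N/N=C(/C)c2ccccc2)CC1` differs from compound 1 by a group of 9 heavy atoms (8 carbon, 1 nitrogen; one six-membered aromatic ring of carbon only) in place of one nitrogen atom, on an amide-type nitrogen. The step from compound 1 to compound 2 is the only one that bears on this change, and a step of similar size and direction, an at least 2.0-fold lower number from compound 1 to compound 3 (0.30 log units; that floor lies within the scatter), is therefore expected. Compound 3 is estimated at 50000 nM in this assay, within 15000 nM to 150000 nM.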

Compound 3, concentration lethal to 50% of the cells: > 100000 nM
Compound 3 gave a limit, no number; the forecaster's own chance of this, stated with the estimate: 25%; at least 2.0-fold (0.30 log units) between middle value and limit.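

Not every group of this size on the amide-type nitrogen lowers the number in this assay, as the change from the chlorine-bearing group to that of compound 3 gives an at least 2.1-fold higher number from compound 2 to compound 3 (0.33 log units; beyond the scatter). The value of compound 3 is a limit, not a number, so its step from compound 1 cannot be read. Most of the series now sits at that limit: the limit of > 100000 nM in this assay, at which 2 of the 3 values shown sit.

The compounds shown leave open whether the chlorine of compound 2 or the extra methyl group of compound 3 carries this step. They also leave open how a bromine or a methoxy group in place of that chlorine would read.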